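Swapping methyl for tert-butyl in the series

This account rests on a few compounds, and the source may have more. Where it says the series, first, only, none or still open, it means among the compounds named here.

Measured in a functional assay on A549 cells (Homo sapiens) for antiproliferative activity, read by MTT assay, with a stated time of 72 h; a higher number here means a weaker inhibitor, a lower number a stronger inhibitor:
- compound 1 `CC(C)(C)c1ccc(SC(=S)N2CCCCC2)cc1`: 9130 nM
- compound 2 `Cc1ccc(SC(=S)N2CCN(C(=O)OC(C)(C)C)CC2)cc1`: 2110 nM

Of these two numbers, compound 2 at 2110 nM holds the lower, and so is the stronger inhibitor. Its gap to compound 1 lies beyond the usual scatter. The two compounds differ in more than one place, so this gap cannot be assigned to any single change.

The next compound is compound 3 `CC(C)(C)OC(=O)N1CCN(C(=S)Sc2ccc(C(C)(C)C)cc2)CC1`. It has tert-butyl in place of methyl on an aromatic carbon of compound 2, para to a large group: tert-butyl in place of methyl on an aromatic carbon. For the measured compounds named here, no measured pair isolates this change. Going by the values given here, the only related evidence is that compound 1, which also carries tert-butyl, gives 9130 nM in this assay. That gives a slight lean towards a higher number, but no step beyond the scatter is expected.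

The estimate means an expected step of a 1.3-fold higher number from compound 2 to compound 3 (0.12 log units; within the scatter). For compound 3 the expected value is 2800 nM, with an estimated range of 900 nM to 9000 nM.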

Compound 3, half-maximal inhibitory concentration: 769 nM
Compound 3: the middle estimate sits 3.6-fold (0.56 log units) above what was measured; measured number below the stated range.
By their numbers in this assay, from the lowest: compound 3; then compound 2; then compound 1.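

In this assay, tert-butyl in place of methyl on an aromatic carbon, para to a large group, gives a 2.7-fold lower number from compound 2 to compound 3 (0.44 log units; beyond the scatter), so this position accepts the larger carbon group, and in this pair the number falls rather than rises. Tert-butyl at this place does not fix the number by itself: compound 1, which also carries it, gives 9130 nM, while compound 3 gives 769 nM, so the rest of the molecule also counts, and the gain from the change is established only with the remainder of compound 2 in place. Nothing available so far speaks to why the number moves in this direction at this position.

Still open, on these data alone, is whether the step depends on the size of the carbon group or on something else, which an isopropyl group, a cyclohexyl group or a longer chain at the same place would help to separate. Also open, as far as these compounds go, is how groups of another kind behave here, such as a methoxy group, a chlorine atom, an amine or a carboxylic acid, and whether the step carries over to the scaffold of compound 1.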